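Biphenyl replaces chlorophenyl on the chalcone-type carbonyl

The compounds below may be only part of what the source reports. "The series", "measured", "known", "first", "only" and "open" are said of these compounds alone.

Measured compounds:
compound 1 `COc1ccc(/C=C/c2cc(OC)cc(OC)c2/C=C/C(=O)c2cccc(Cl)c2)cc1`: 3.3 ug/mL
compound 2 `COc1ccc(/C=C/c2cc(OC)cc(OC)c2/C=C/C(=O)c2ccc(F)cc2)cc1`: 5.3 ug/mL
compound 3 `COc1ccc(/C=C/c2cc(OC)cc(OC)c2/C=C/C(=O)c2ccc(C)c(C)c2)cc1`: 1.4 ug/mL

All three share one core and differ only in the aryl group on the carbonyl carbon. In a functional assay on B16-F10 cells (Mus musculus) for antiproliferative activity, read by MTT assay, with a stated time of 48 h (a higher number here means a weaker inhibitor, a lower number a stronger inhibitor), compound 1 gives 3.3 ug/mL, the second highest of the three numbers; compound 2 gives 5.3 ug/mL, and a 1.6-fold higher number from compound 1 to compound 2 (0.21 log units; within the scatter). Compound 3 gives 1.4 ug/mL, and a 2.4-fold lower number from compound 1 to compound 3 (0.37 log units; beyond the scatter); likewise a 3.8-fold lower number from compound 2 to compound 3 (0.58 log units; beyond the scatter).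

Compound 4 `COc1ccc(/C=C/c2cc(OC)cc(OC)c2/C=C/C(=O)c2ccc(-c3ccccc3)cc2)cc1` has not been measured. It differs from compound 1 in one place: 4-phenylphenyl in place of 3-chlorophenyl on a carbonyl carbon. Among the compounds with values here, no measured step introduces a second aromatic ring on that carbonyl carbon, so the bearing of the measured steps is indirect: swapping one halogenated phenyl for another stayed within the scatter, while the dimethyl-bearing phenyl gave a modest step to lower numbers. A larger aryl group is expected to land near compound 1, and compound 4 is therefore estimated at 3.5 ug/mL, in the range 1.3 ug/mL to 9 ug/mL, which means an expected step of a 1.1-fold higher number from compound 1 to compound 4 (0.03 log units; within the scatter), not beyond the scatter.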

Compound 4, half-maximal inhibitory concentration: 10.6 ug/mL
Compound 4: middle estimate off by 3.0-fold (0.48 log units), on the low side; the measured number lies above the stated range.
By their numbers in this assay, from the lowest: compound 3; then compounds 1, 2 and 4 (each within the scatter of the next, the first and the last beyond it).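

In this assay, within the data shown here, 4-phenylphenyl on the carbonyl carbon gives the first step to a higher number at this position that lies beyond the scatter from compound 1, a 3.2-fold higher number from compound 1 to compound 4 (0.51 log units; beyond the scatter), and it widens the spread of the series, with a 7.6-fold higher number from compound 3 to compound 4 (0.88 log units; beyond the scatter). Phenyl in place of fluoro on an aromatic carbon gives a 2.0-fold higher number from compound 2 to compound 4 (0.30 log units; within the scatter), so the second ring does not separate these two compounds, and compound 3 remains the strongest inhibitor of the four. Nothing available here explains why the number rises with this group.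

The compounds shown leave open whether the second ring itself or its place on the first ring sets the result. They also leave open how an amine, a carboxylic acid or a longer alkyl chain on that aryl group would read in this assay.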